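Nitro in Place of Chloro: Expected Cytotoxicity of Compound 4

This account rests on a few compounds, and the source may have more. Where it says the series, first, only, none or still open, it means among the compounds named here.

Measured compounds:
Compound 1 `Cc1cc(C)cc(S(=O)(=O)c2c(C(=O)NCN3CCCC3)[nH]c3ccc(Cl)cc23)c1` gives 11000 nM in an ADME assay on CCRF-CEM cells (Homo sapiens) for cytotoxicity, read by cell counting; on this read-out higher numbers stand for lower toxicity in this test and lower numbers for higher toxicity in this test.
Compound 2 `Cc1cc(C)cc(S(=O)(=O)c2c(C(=O)NCCOc3ccccc3)[nH]c3ccc(Cl)cc23)c1` gives 207000 nM in this assay.
Compound 3 `Cc1cc(C)cc(S(=O)(=O)c2c(C(=O)NCCOc3ccccc3)[nH]c3ccc(Cl)c(F)c23)c1` gives 11000 nM in this assay.

Among these three, compound 2 stands highest, and so is the least toxic in this test. Its nearest neighbours are both far away: a 19-fold higher number from compound 1 to compound 2 (1.27 log units; beyond the scatter), and a 19-fold lower number from compound 2 to compound 3 (1.27 log units; beyond the scatter).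

Compound 4 `Cc1cc(C)cc(S(=O)(=O)c2c(C(=O)NCCOc3ccccc3)[nH]c3ccc([N+](=O)[O-])cc23)c1` has not been measured. It differs from compound 2 in one place: nitro in place of chloro on an aromatic carbon.

Two measured steps give some guidance. The step from compound 1 to compound 2 changed a chain group, not the aromatic core, so it says little about the present change. The step from compound 2 to compound 3 changed a substituent on the aromatic core, as the present change does, and it was large, moving towards higher toxicity. Nitro for chloro is a different swap from fluoro for hydrogen, so the direction is not assured, but the one core-ring change seen was large and downward. A moderate move towards lower numbers is therefore expected, with wide uncertainty.

For compound 4 the expected value in this assay is 40000 nM, ranging from 8000 nM to 200000 nM. That estimate means an expected step of a 5.2-fold lower number from compound 2 to compound 4 (0.71 log units; beyond the scatter).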

Compound 4, half-maximal cytotoxic concentration: > 500000 nM
Compound 4 ended at the assay's limit (the forecaster's own chance of this, stated with the estimate: 5%); at least 12-fold (1.09 log units) between middle value and limit.
By their numbers in this assay, from the lowest: compounds 1 and 3 (each within the scatter of the next); then compound 2. At a limit, above all of these: compound 4.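

In this assay compound 4 stands at a limit of the assay and not at a number: the limit of > 500000 nM in this assay, at which 1 of the 4 values shown sits.

Nitro in place of chloro on this aromatic carbon gives an at least 2.4-fold higher number from compound 2 to compound 4 (0.38 log units; beyond the scatter) so the true size of the move remains open, although its direction is clear: the number rises, which means lower toxicity in this test. The only other change shown on an aromatic carbon of the shared core, fluoro in place of hydrogen, gave a 19-fold lower number from compound 2 to compound 3 (1.27 log units; beyond the scatter) and so went the opposite way, which shows that changes on this core can move the read-out in either direction.

The compounds shown leave open whether the rise belongs to nitro in particular, since only chloro and nitro appear at this place, and an amine or a nitrile on the same aromatic carbon would help to settle that. They also leave open whether the same swap would act alike on the pyrrolidin-1-yl chain of compound 1, or whether it holds only with the phenoxy-bearing chain shared by compound 2 and compound 4.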